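Dropping the nitro group: what cytotoxicity to expect

This account rests on a few compounds, and the source may have more. Where it says the series, first, only, none or still open, it means among the compounds named here.

Measured so far in an ADME assay on HEL cells (Homo sapiens) for cytotoxicity; on this read-out lower numbers stand for higher toxicity in this test and higher numbers for lower toxicity in this test:
compound 1 `O=C(COc1cccc2ccccc12)N/N=C/c1cccc([N+](=O)[O-])c1` — >= 20 ug/mL, a limit of the test (the limit of >= 20 ug/mL in this assay, at which 1 of the 3 values shown sits)
compound 2 `C/C(=N\NC(=O)COc1cccc2ccccc12)c1ccc(O)cc1O` — > 100 ug/mL, a limit of the test (the limit of > 100 ug/mL in this assay, at which 1 of the 3 values shown sits)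
compound 3 `C/C(=N\NC(=O)COc1cccc2ccccc12)c1ccc([N+](=O)[O-])cc1` — 100 ug/mL

Compound 1 therefore stands only at a limit, with no exact number in this assay. Among the measured compounds shown here, the one measured step, a number no higher from compound 2 to compound 3 (the limit leaves the size open), is the only change that touches a nitro group, and its size cannot be read. Compound 4 `O=C(COc1cccc2ccccc12)N/N=C/c1ccccc1` differs from compound 1 by hydrogen in place of nitro on an aromatic carbon. With no readable step to lean on, no change beyond the scatter is expected in this assay, so a step that the limit leaves unreadable from compound 1 to compound 4 is the expected step. Compound 4 is estimated at 60 ug/mL, between 20 ug/mL and 100 ug/mL.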

Compound 4, minimum cytotoxic concentration: 100 ug/mL
The estimate for compound 4 lay 1.7-fold (0.22 log units) below the measured number; the range from low to high includes it.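

In this assay, no new step can be read between compound 1 and compound 4, because compound 1 stands only at a limit: the limit of >= 20 ug/mL in this assay, at which 1 of the 4 values shown sits.

The compounds shown leave open how large the change is when hydrogen replaces nitro on this aromatic carbon.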